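Working notes: methyl removal across two amine variants

The compounds below may be only part of what the source reports. "The series", "measured", "known", "first", "only" and "open" are said of these compounds alone.

Measured so far in a functional assay on HeLa cells (Homo sapiens) for antiproliferative activity, read by MTT assay, with a stated time of 72 h; on this read-out higher numbers stand for weaker inhibition and lower numbers for stronger inhibition:
compound 1 `O=c1c(CSC(=S)N2CCCC2)coc2ccccc12`: > 25000 nM
compound 2 `Cc1ccc2c(=O)c(CSC(=S)N3CCCC3)coc2c1`: 4400 nM
compound 3 `Cc1ccc2c(=O)c(CSC(=S)N(C(C)C)C(C)C)coc2c1`: 1400 nM

The value of compound 1 is a limit of this assay and not a number (the limit of > 25000 nM in this assay, at which 1 of the 3 values shown sits). Compound 2 and compound 1 differ by hydrogen in place of methyl on an aromatic carbon, and the step is an at least 5.6-fold higher number from compound 2 to compound 1 (0.75 log units; beyond the scatter). Compound 2 and compound 3 differ in the core by diisopropylamino in place of pyrrolidin-1-yl on a thiocarbonyl carbon, giving a 3.1-fold lower number from compound 2 to compound 3 (0.50 log units; beyond the scatter); compound 3 has the lowest number among the two measured values.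

Compound 4 `CC(C)N(C(=S)SCc1coc2ccccc2c1=O)C(C)C` is not yet measured. It differs from compound 3 by hydrogen in place of methyl on an aromatic carbon, the same change as from compound 2 to compound 1, with an identical place. The expectation for compound 4 rests on compound 2 and compound 1, where the step was an at least 5.6-fold higher number from compound 2 to compound 1 (0.75 log units; beyond the scatter); the expected step is a 7.1-fold higher number from compound 3 to compound 4 (0.85 log units; beyond the scatter). Compound 4 is therefore estimated at 10000 nM in this assay, with a range of 3500 nM to 30000 nM, and a real chance that only a limit is reported.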

Compound 4, half-maximal inhibitory concentration: > 30000 nM
Compound 4 ended at the assay's limit (the forecaster's own chance of this, stated with the estimate: 30%); at least 3.0-fold (0.47 log units) between middle value and limit.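

In this assay, hydrogen in place of methyl on the aromatic carbon weakens inhibition in the diisopropylamino series as well, an at least 21-fold higher number from compound 3 to compound 4 (1.33 log units; beyond the scatter), and the step between compound 1 and compound 4 cannot be read. Going by these compounds, compound 4 gives > 30000 nM, which is a limit of the assay and not a number, so the true size of this step remains unknown. The direction of the change therefore carries over between the pyrrolidin-1-yl and diisopropylamino compounds, but these two pairs do not show that its size carries over, or that it would hold on any other core: the same change on two cores in this assay, an at least 5.6-fold higher number (0.75 log units; beyond the scatter) from compound 2 to compound 1 and an at least 21-fold higher number (1.33 log units; beyond the scatter) from compound 3 to compound 4; the limit leaves it open whether they differ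

The compounds shown leave open whether another group on that aromatic carbon, such as ethyl, chloro or methoxy, would keep the inhibition seen with methyl. They also leave open how other amines on the thiocarbonyl carbon, such as morpholine or piperidine, would behave with the methyl present or absent.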